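The source may hold more compounds than are shown below. What is called first, only, known or untested is meant among the compounds shown, and "the series" means these compounds.

Working notes on the series. For the measured compounds named here, in a functional assay on PC-3 cells (Homo sapiens) for inhibition (on this read-out higher numbers stand for weaker inhibition and lower numbers for stronger inhibition), compound 2 `COc1cc2nc(N3CCN(S(=O)(=O)c4ccc(C(=O)O)cc4)CC3)nc(N)c2cc1OC` gives 53000 nM, the highest of the two numbers so far; the only neighbour, compound 1 `COc1cc2nc(N3CCN(S(=O)(=O)c4ccc(I)cc4)CC3)nc(N)c2cc1OC`, gives 15000 nM in this assay. Going by the values given here, the single measured step, a 3.5-fold higher number from compound 1 to compound 2 (0.55 log units; beyond the scatter), exchanged iodo for carboxy on the aromatic carbon and moved the number modestly upward. Compound 3 `COc1cc2nc(N3CCN(S(=O)(=O)c4ccc(-c5ccccc5)cc4)CC3)nc(N)c2cc1OC` is the next member; it differs from compound 2 by phenyl in place of carboxy on an aromatic carbon. That step bears directly on the carboxy read-out: the group that entered in compound 2 now leaves, and what enters brings, as counted, no hydrogen-bond donor and no acceptor, as with the iodo of compound 1. The expectation is therefore a reversal of roughly the size of the measured step, the number falling back toward compound 1, with the step of a 4.4-fold lower number from compound 2 to compound 3 (0.65 log units; beyond the scatter) expected in this assay. For compound 3 an estimated value of 12000 nM is expected, within a range from 3500 nM to 40000 nM.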

Compound 3, half-maximal inhibitory concentration: 4200 nM
For compound 3 the middle estimate is 2.9-fold (0.46 log units) above the measured one, within the range that was stated.
By their numbers in this assay, from the lowest: compound 3; then compound 1; then compound 2.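

In this assay the step of a 13-fold lower number from compound 2 to compound 3 (1.10 log units; beyond the scatter) is large, and phenyl does more than undo the carboxy change: the step of a 3.6-fold lower number from compound 1 to compound 3 (0.55 log units; beyond the scatter) takes the number past that of the iodo compound. On this position, para to a large group, two groups with no hydrogen-bond donor or acceptor as counted therefore differ beyond the scatter, so that count alone does not order the three compounds. Nothing shown explains these differences.

Still open, on these data alone, is whether the lower number with 4-phenylphenyl needs an aromatic ring at all, which cyclohexyl at the same position would test, and whether a substituent on the added ring, such as an amine or a carboxylic acid, keeps it. A methyl ester or primary amide in place of carboxy would show whether the high number of compound 2 belongs to the free acid.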